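The source may hold more compounds than are shown below. What is called first, only, known or untested is meant among the compounds shown, and "the series" means these compounds.

Compound 1 `C=C(Br)C(=O)Nc1ccc(/C=C/C(=O)c2ccc(OC)cc2)cc1` and compound 2 `C=C(Br)C(=O)Nc1ccc(C(=O)/C=C/c2ccccc2)cc1` both carry a (1-bromoethenyl)carbonyl group on an aromatic nitrogen, but they are built on different cores; the difference between the two cores is not broken down here. In a functional assay on MOLT-4 cells (Homo sapiens) for antiproliferative activity, with a stated time of 48 h (a higher number here means a weaker inhibitor, a lower number a stronger inhibitor), compound 1 gives 1300 nM, while compound 2 gives 500 nM, the lowest number of the three measured compounds. Compound 3 `COc1ccc(C(=O)/C=C/c2ccc(N)cc2)cc1` is compound 1 stripped of that group: hydrogen in place of (1-bromoethenyl)carbonyl on a nitrogen on an aromatic ring. The effect of this change is large, a 15-fold higher number from compound 1 to compound 3 (1.16 log units; beyond the scatter), so that compound 3 gives 19000 nM in this assay.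

Compound 4 `Nc1ccc(C(=O)/C=C/c2ccccc2)cc1` stands to compound 2 exactly as compound 3 stands to compound 1: hydrogen in place of (1-bromoethenyl)carbonyl on a nitrogen on an aromatic ring. The place of the change is the same in both pairs, a nitrogen on an aromatic ring whose other neighbour is an aromatic carbon. If the change acts on the core of compound 2 as it did on the core of compound 1, an upward step a 14-fold higher number from compound 2 to compound 4 (1.15 log units; beyond the scatter) is expected, because the earlier step of a 15-fold higher number from compound 1 to compound 3 (1.16 log units; beyond the scatter) was large and beyond the scatter. On that basis compound 4 is estimated to give 7000 nM in this assay, with a plausible range from 2500 nM to 25000 nM.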

Compound 4, half-maximal inhibitory concentration: 7900 nM
Estimate against measurement, compound 4: 1.1-fold (0.05 log units) below, and the stated range covers the measured number.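

Replacing (1-bromoethenyl)carbonyl with hydrogen on a nitrogen on an aromatic ring gives a 16-fold higher number from compound 2 to compound 4 (1.20 log units; beyond the scatter) in this assay and thus repeats on a second core what was seen on the first: the same change on two cores in this assay, a 15-fold higher number (1.16 log units; beyond the scatter) from compound 1 to compound 3 and a 16-fold higher number (1.20 log units; beyond the scatter) from compound 2 to compound 4, 1.1-fold (0.03 log units) apart, within the scatter of two such steps. Within this series, then, the size of the step carries over from the core of compound 1 to the core of compound 2, and a step read on one of these cores would have served for the other. Within the data shown here, this rests on only two pairs in a single assay, however, so it does not show that the step would keep its size on a further core, nor does it show why removing the group has this effect or which of its atoms matter.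

The compounds shown leave open whether a simpler acyl group on that nitrogen, such as acetyl, or the same group with chlorine in place of bromine, would give numbers like those of compound 1 and compound 2. They also leave open how the step behaves on a core carrying other substituents, such as a hydroxyl group or a fluorine.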